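A few compounds are considered here, and "the series" means these few. Any claim that something is new, unique, unknown or untested is made for them only; others in the source may bear on it.

Measured in an ADME assay on HepG2 cells (Homo sapiens) for cytotoxicity, read by MTT assay, with a stated time of 72 h; on this read-out lower numbers stand for higher toxicity in this test and higher numbers for lower toxicity in this test:

- Compound 1 `O=[N+]([O-])c1c(CS(=O)(=O)c2ccccc2)nc2c(C#Cc3cccc(F)c3)cc(Cl)cn12`: > 3900 nM, a limit
- Compound 2 `O=[N+]([O-])c1c(CS(=O)(=O)c2ccccc2)nc2c(C#Cc3cccs3)cc(Cl)cn12`: > 3900 nM, a limit
- Compound 3 `CC(O)(C#Cc1cc(Cl)cn2c([N+](=O)[O-])c(CS(=O)(=O)c3ccccc3)nc12)c1ccccc1`: 18800 nM

Compound 2 has only a limit, > 3900 nM, rather than a number. Compound 4 `CC(C)(O)C#Cc1cc(Cl)cn2c([N+](=O)[O-])c(CS(=O)(=O)c3ccccc3)nc12` differs from it in one group: 1-hydroxy-1-methylethyl in place of thiophen-2-yl on a triple-bonded carbon. The measured change closest to this is a step that the limit leaves unreadable from compound 2 to compound 3, so it gives no usable size. Still, 1-hydroxy-1-phenylethyl is the measured group nearest to 1-hydroxy-1-methylethyl, so compound 4 is expected to resemble compound 3 at 18800 nM. The expected change is a step that the limit leaves unreadable from compound 2 to compound 4, in the direction of lower toxicity in this assay. For compound 4 the estimate is 20000 nM, with an expected range of 6000 nM to 60000 nM.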

Compound 4, half-maximal cytotoxic concentration: > 62500 nM
Compound 4 was reported as a limit; the forecaster's own chance of this, stated with the estimate: 45%; at least 3.1-fold (0.49 log units) between middle value and limit.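

In this assay methyl in place of phenyl on the saturated chain carbon gives an at least 3.3-fold higher number from compound 3 to compound 4 (0.52 log units; beyond the scatter) as the first readable step among these alkyne groups, and it points toward lower toxicity in this test. The value of compound 4 is a limit: the limit of > 62500 nM in this assay, at which 1 of the 4 values shown sits.
The steps to compound 4 from compound 1 and from compound 2 cannot be read.

From the compounds shown here alone, with only phenyl and methyl compared on that carbon, it remains open whether the step follows from removing the ring or from another difference. Going by these compounds, how an amine or a longer chain there would read also stays open.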